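From compound 2 to compound 3: one ring swap

A few compounds are considered here, and "the series" means these few. Any claim that something is new, unique, unknown or untested is made for them only; others in the source may bear on it.

Values in a physicochemical assay for lipophilicity; a higher number here means a more lipophilic compound, a lower number a more polar compound:
- compound 1 `Cn1nccc1-c1cc(C(F)(F)F)ccc1[C@H]1CCOc2cc(S(=O)(=O)Nc3nccs3)ccc21`: 2.2
- compound 2 `O=S(=O)(Nc1nccs1)c1ccc2c(c1)OCC[C@@H]2c1ccc(C(F)(F)F)cc1-c1ccc(F)cc1`: 4.5

Compound 2 stands highest of these two. Compound 3 `O=S(=O)(Nc1nccs1)c1ccc2c(c1)OCC[C@@H]2c1ccc(C(F)(F)F)cc1-c1ccc(F)cn1` differs from it in one place: 5-fluoropyridin-2-yl in place of 4-fluorophenyl on an aromatic carbon. Among the compounds with values here, only one measured step changes the ring on this aromatic carbon: a number 2.30 log units higher from compound 1 to compound 2 (beyond the scatter), which is large. It offers a single comparison: compound 1, with 1-methyl-1H-pyrazol-5-yl, has the lower number, 2.2. The 5-fluoropyridin-2-yl ring is closer in name and count to 4-fluorophenyl, so a smaller, downward move is expected: a number 0.90 log units lower from compound 2 to compound 3 (beyond the scatter). In this assay, compound 3 is estimated at 3.6, within 3.1 to 4.1.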

Compound 3, distribution coefficient: 3.5
Beside the measured number, compound 3's estimate is 0.10 log units above it, and the stated range covers the measured number.
By their numbers in this assay, from the lowest: compound 1; then compound 3; then compound 2.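

In this assay the 5-fluoropyridin-2-yl ring has the same heavy-atom count as 4-fluorophenyl and differs by one nitrogen in place of a carbon, yet it still gives a number 1.00 log units lower from compound 2 to compound 3 (beyond the scatter) at this aromatic carbon. Set against 1-methyl-1H-pyrazol-5-yl, the same ring gives a number 1.30 log units higher from compound 1 to compound 3 (beyond the scatter) and so stands apart from both other rings. Nothing available here explains these differences. Still open, going by these compounds, is how this aromatic carbon would respond to a ring bearing an amine or a carboxylic acid, or to a simple ethyl chain in place of a ring.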